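The compounds below may be only part of what the source reports. "The series", "measured", "known", "first", "only" and "open" are said of these compounds alone.

The series under study shares one core and varies in its side groups. In an ADME assay on microsomes from liver (Mus musculus) for metabolic stability, read by LC-MS, using NADPH, with stated times of 15 min and 60 min, tested at 4.6 uM (a lower number here means that the compound disappears faster, a higher number that the compound lasts longer), compound 1 `CC(C)N1CCC(c2ccc3c(c2)oc(=O)n3C(=O)NCCCCc2ccccc2)CC1` gives 1 h, compound 2 `CN1CCC(c2ccc3c(c2)oc(=O)n3C(=O)NCCCCc2ccccc2)CC1=O` gives 0.583 h and compound 3 `CC(C)CNC(=O)n1c(=O)oc2c(C3CCN(C)CC3)cccc21` gives 0.5 h. Compound 2 therefore stands within the scatter of both other compounds, so these three numbers do not separate it from either one.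

The next compound to be measured is compound 4 `CC(C)CN1CCC(c2ccc3c(c2)oc(=O)n3C(=O)NCCCCc2ccccc2)CC1`, and the change leading to it from compound 2 is 1-isobutylpiperidin-4-yl in place of 1-methyl-2-oxopiperidin-4-yl on an aromatic carbon. For the measured compounds named here, no compound carrying 1-isobutylpiperidin-4-yl on this core has a measured value yet. Going by the values given here, the one measured step that bears on the change is a 1.7-fold lower number from compound 1 to compound 2 (0.23 log units; within the scatter). That step brings in the same 1-methyl-2-oxopiperidin-4-yl that compound 4 gives up, replacing 1-isopropylpiperidin-4-yl, and it stays within the scatter. The entering group is closer in structure to the 1-isopropylpiperidin-4-yl of compound 1 than to the group it replaces, so any shift is expected to point weakly towards the number of compound 1. The expected size is a 1.3-fold higher number from compound 2 to compound 4 (0.11 log units; within the scatter), with no step beyond the scatter anticipated. For compound 4 the estimated half-life is 0.75 h, with an expected range from 0.35 h to 1.6 h.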

Compound 4, half-life: 1 h
For compound 4 the middle estimate is 1.3-fold (0.12 log units) below the measured one; measured number inside the range.
By their numbers in this assay, from the lowest: compounds 3, 2, 1 and 4 (each within the scatter of the next).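

In this assay, the exchange on the aromatic carbon reads as a 1.7-fold higher number from compound 2 to compound 4 (0.23 log units; within the scatter) and so does not separate 1-isobutylpiperidin-4-yl from 1-methyl-2-oxopiperidin-4-yl on the shared core. For the compounds shown here, the new pair of compounds 1 and 4 isolates the substituent on the ring amine nitrogen for the first time, and isobutyl in place of isopropyl reads as no change at the digits printed from compound 1 to compound 4 (within the scatter) with the rest of the structure unchanged, so these two branched groups cannot be told apart in this read-out. No available evidence bears on why either step has the size it has.

Every step shown at this position lies within the scatter, so it remains open whether any substituent here can move the half-life beyond it. The compounds shown also leave unanswered how a longer chain, a benzyl group or a cyclopropylmethyl group on the ring nitrogen would read, and whether a carboxylic acid or a primary amine on the piperidine ring would read any differently.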